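Swapping the arylalkyne for a pyridyl in mGlu5 modulators

The source may hold more compounds than are shown below. What is called first, only, known or untested is meant among the compounds shown, and "the series" means these compounds.

Compound 1 `Cc1cccc(C#Cc2ccc3c(n2)CCN(C2CCCC2)C3=O)c1`: 7.5 nM
Compound 2 `Cc1ccc(C#Cc2ccc3c(n2)CCN(C2CCCC2)C3=O)cc1`: 4820 nM

In a functional assay on HEK293 cells for positive allosteric modulation of metabotropic glutamate receptor 5 (Homo sapiens), read by FLIPR and calcium flux (a lower number here means that less compound is needed, a higher number that more compound is needed for the effect), compound 2 stands highest of the two numbers measured; the step of a 640-fold higher number from compound 1 to compound 2 (2.81 log units; beyond the scatter) separates it from compound 1. Compound 3 `O=C1c2ccc(C#Cc3cccnc3)nc2CCN1C1CCCC1` differs from compound 2 by pyridin-3-yl in place of 4-methylphenyl on a triple-bonded carbon. Within the data shown here, no measured step touches this exchange: the only step known changes the position of a methyl on the ring, not the ring itself, so it gives no direct guide. The outcome is therefore estimated with wide bounds, leaning toward a lower number, a 12-fold lower number from compound 2 to compound 3 (1.08 log units; beyond the scatter). Compound 3 is expected to give 400 nM, within 40 nM to 4000 nM.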

Compound 3, half-maximal effective concentration: 748 nM
Compound 3: the middle estimate sits 1.9-fold (0.27 log units) below what was measured, within the range that was stated.
By their numbers in this assay, from the lowest: compound 1; then compound 3; then compound 2.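

In this assay, among these compounds, the earlier compounds varied only the place of a methyl on the ring, whereas pyridin-3-yl changes the ring itself, with a 6.4-fold lower number from compound 2 to compound 3 (0.81 log units; beyond the scatter). The same group still falls far short of 3-methylphenyl on the triple-bonded carbon, with a 100-fold higher number from compound 1 to compound 3 (2.00 log units; beyond the scatter), so at this position, a ring with a hetero atom does not match the better methylphenyl. No evidence is available to explain either step. On these data alone, whether pyridin-2-yl or 3-chlorophenyl at this place would come closer to compound 1 remains open.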